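Changing the Chain End Two Bonds from the Ring Amine

This account rests on a few compounds, and the source may have more. Where it says the series, first, only, none or still open, it means among the compounds named here.

Three measured compounds share one core and differ only at a saturated chain carbon bound to an amine nitrogen in a ring. Compound 1 `Cc1ccc(-c2nnc(-c3ccc(CN4CCN(C)CC4)c(C(F)(F)F)c3)o2)cc1Nc1nccc(-c2cccnc2)n1` carries a hydrogen there, and in a functional assay on K562 cells (Homo sapiens) for inhibition, read by MTT assay, with a stated time of 72 h (a lower number here means a stronger inhibitor, a higher number a weaker inhibitor), compound 1 gives 510 nM. Compound 2 `Cc1ccc(-c2nnc(-c3ccc(CN4CCN(CCN)CC4)c(C(F)(F)F)c3)o2)cc1Nc1nccc(-c2cccnc2)n1` carries aminomethyl at that carbon, and in this assay compound 2 gives 300 nM, a step of a 1.7-fold lower number from compound 1 to compound 2 (0.23 log units; within the scatter). Compound 3 `Cc1ccc(-c2nnc(-c3ccc(CN4CCN(CCN=C=S)CC4)c(C(F)(F)F)c3)o2)cc1Nc1nccc(-c2cccnc2)n1` carries a group of 4 heavy atoms at the same carbon, and in this assay compound 3 gives 500 nM. Among the three numbers, compound 3 sits closest to compound 1, with the step of a 1.0-fold lower number from compound 1 to compound 3 (0.01 log units; within the scatter), and its distance from compound 2, the step of a 1.7-fold higher number from compound 2 to compound 3 (0.22 log units; within the scatter), also stays inside the scatter; none of the three substitutions shifted the read-out in a meaningful way.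

Compound 4 `C=CC(=O)NCCN1CCN(Cc2ccc(-c3nnc(-c4ccc(C)c(Nc5nccc(-c6cccnc6)n5)c4)o3)cc2C(F)(F)F)CC1` has not been measured. It differs from compound 3 by a group of 5 heavy atoms (3 carbon, 1 nitrogen, 1 oxygen; no ring) in place of a group of 3 heavy atoms (1 carbon, 1 nitrogen, 1 sulfur; no ring), on a saturated chain carbon, two bonds along the chain from an amine nitrogen in a ring. All three measured steps concern this same region of the molecule and all were small, so no step beyond the scatter is expected here either. Compound 4 is expected to give about 400 nM in this assay, most likely between 200 nM and 800 nM. The estimated step of a 1.3-fold lower number from compound 3 to compound 4 (0.10 log units; within the scatter) is expected to remain within the scatter.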

Compound 4, half-maximal inhibitory concentration: 600 nM
Beside the measured number, compound 4's estimate is 1.5-fold (0.18 log units) below it; measured number inside the range.
By their numbers in this assay, from the lowest: compounds 2, 3, 1 and 4 (each within the scatter of the next).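

With compound 4, the chain end two bonds along from the ring amine now holds (vinylcarbonyl)amino, a group of 5 heavy atoms with 1 hydrogen-bond donor, where the end group of compound 3 has 3 heavy atoms and no donor, and the result is a 1.2-fold higher number from compound 3 to compound 4 (0.08 log units; within the scatter) in this assay, so this larger end group also leaves the read-out inside the scatter. Placing vinylcarbonyl on the amine nitrogen gives a 2.0-fold higher number from compound 2 to compound 4 (0.30 log units; within the scatter) and the whole ((vinylcarbonyl)amino)methyl group in place of hydrogen gives a 1.2-fold higher number from compound 1 to compound 4 (0.07 log units; within the scatter), which means all four compounds now read alike at this position despite these different chain ends. No supporting measurement is available to explain why these chain ends read alike.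

The compounds shown leave open whether any group at this place would produce a step beyond the scatter, for example a carboxylic acid at the chain end or a longer chain before the amide. They also leave open whether a saturated propanoyl group in place of vinylcarbonyl would give a similar number.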